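Same Branching Swap, Tried on a Silent Core

The source may report more compounds than this note shows. Statements on the series, on what has been measured and on what is new or still open speak of the compounds shown alone.

Measured so far:
compound 1, `CCCOC(=O)c1c(NC(=O)N2CCN(C)CC2)sc2c1CCC2`: 14200 nM
compound 2, `CC(C)OC(=O)c1c(NC(=O)N2CCN(C)CC2)sc2c1CCC2`: 4590 nM
compound 3, `CCCOC(=O)c1c(NC(=S)N2CCN(C)CC2)sc2c1CCCC2`: "not active" (no number reported)

In an assay on cells for agonist activity at Toll-like receptor 2 (Homo sapiens), with a stated time of 24 h (a lower number here means that less compound is needed, a higher number that more compound is needed for the effect), compound 1 gives 14200 nM, while compound 2 gives 4590 nM. The two share a core and differ in one place only: isopropyl in place of propyl on an oxygen next to a carbonyl group. That single swap produced a 3.1-fold lower number from compound 1 to compound 2 (0.49 log units; beyond the scatter), so branching the chain on the ester oxygen helped here.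

Compound 3 stands on a different core; the difference between the core of compound 1 and the core of compound 3 is not broken down here. In this assay, from the compounds shown here alone, compound 3 is reported as "not active" (no number reported), with no number attached, so its position on the scale is unknown.

Compound 4, `CC(C)OC(=O)c1c(NC(=S)N2CCN(C)CC2)sc2c1CCCC2`, has not yet been measured. It relates to compound 3 exactly as compound 2 relates to compound 1: isopropyl in place of propyl on an oxygen next to a carbonyl group. The place is the same in words, so this is the same change, seen a second time.

The step from compound 1 to compound 2 was modest, and compound 3 gave no measurable number at all. A modest gain on an unmeasurable starting point may or may not bring compound 4 into the measurable range. Compound 4 is therefore expected to land near 40000 nM in this assay, with a wide span from 8000 nM to 200000 nM, and a real chance that only "not active" is reported again.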

Compound 4, half-maximal effective concentration: 45200 nM
Estimate against measurement, compound 4: 1.1-fold (0.05 log units) below; the range from low to high includes it.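

No new step can be read from compound 3 to compound 4: in this assay compound 3 is reported only as "not active", with no number, while compound 4 gives a number (45200 nM). The compounds shown leave open how large the change from propyl to isopropyl is on this core, compared with the earlier pair (a 3.1-fold lower number from compound 1 to compound 2 (0.49 log units; beyond the scatter)). No measured evidence here explains the result.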